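Removing the Chloro Group: Expected Effect on Cytotoxicity

A few compounds are considered here, and "the series" means these few. Any claim that something is new, unique, unknown or untested is made for them only; others in the source may bear on it.

Compound 3 `Cc1nnc(SCC(=O)N/N=c2/scc(-c3ccc(Cl)cc3)n2-c2ccccc2)s1` gives 28 ug/mL in a functional assay on C6 cells (Rattus norvegicus) for cytotoxicity, read by MTT assay, with a stated time of 24 h; a lower number here means a stronger inhibitor, a higher number a weaker inhibitor. Among the three measured compounds this is the highest number. Compound 2 `Cc1nnc(SCC(=O)N/N=c2/scc(-c3ccc(F)cc3)n2-c2ccccc2)s1` lies nearest, with 27.3 ug/mL, and a 1.0-fold higher number from compound 2 to compound 3 (0.01 log units; within the scatter) falls within the scatter. Compound 1 `O=C(CSc1nnnn1-c1ccccc1)N/N=c1/scc(-c2ccccc2)n1-c1ccccc1` stands furthest, with 8.3 ug/mL, beyond the scatter from compound 3.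

Compound 4 `Cc1nnc(SCC(=O)N/N=c2/scc(-c3ccccc3)n2-c2ccccc2)s1` differs from compound 3 by hydrogen in place of chloro on an aromatic carbon. For the measured compounds named here, only one measured step touches that ring: a 1.0-fold higher number from compound 2 to compound 3 (0.01 log units; within the scatter) shows that exchanging one halogen for another left the number unchanged within the scatter. Going by the values given here, no measured pair sets a halogen against hydrogen on that ring with the rest of the molecule held constant; compound 1 carries an unsubstituted phenyl ring but also differs elsewhere in the molecule, so its value of 8.3 ug/mL cannot be read as such a step. Since a 1.0-fold higher number from compound 2 to compound 3 (0.01 log units; within the scatter) is within the scatter, compound 4 is expected to stay close to compound 3, with a 1.4-fold lower number from compound 3 to compound 4 (0.15 log units; within the scatter) at most a modest move toward lower numbers. Compound 4 is estimated at 20 ug/mL, with a range from 9 ug/mL to 45 ug/mL.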

Compound 4, half-maximal inhibitory concentration: > 200 ug/mL
Compound 4 gave a limit, no number; the forecaster's own chance of this, stated with the estimate: 5%; middle value at least 10-fold (1.00 log units) from the limit.
By their numbers in this assay, from the lowest: compound 1; then compounds 2 and 3 (each within the scatter of the next). At a limit, above all of these: compound 4.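

In this assay compound 4 gives only a limit, not a number: the limit of > 200 ug/mL in this assay, at which 1 of the 4 values shown sits. On this ring, the change that moves the number is losing the halogen rather than exchanging it: hydrogen in place of chloro gives an at least 7.1-fold higher number from compound 3 to compound 4 (0.85 log units; beyond the scatter), and hydrogen in place of fluoro gives an at least 7.3-fold higher number from compound 2 to compound 4 (0.86 log units; beyond the scatter), while the two halogens themselves read alike. With the unsubstituted phenyl ring held constant, the group on the sulfur also counts, since 5-methyl-1,3,4-thiadiazol-2-yl in place of 1-phenyl-1H-tetrazol-5-yl gives an at least 24-fold higher number from compound 1 to compound 4 (1.38 log units; beyond the scatter).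

The compounds shown leave open whether a halogen as such is needed on that aromatic carbon, or whether a methyl or methoxy group there would serve as well. They also leave open how a 4-chlorophenyl ring would read alongside the 1-phenyl-1H-tetrazol-5-yl group.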